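The source may report more compounds than this note shows. Statements on the series, on what has been measured and on what is new or still open speak of the compounds shown alone.

Measured so far:
compound 1 `O=C(/C=C/c1cn([C@@H]2C[C@H](CO)N(CCCc3ccccc3)C2)nn1)NO`: 12%
compound 2 `O=C(NO)c1cccc(-c2cn([C@@H]3C[C@H](CO)N(CCCc4ccccc4)C3)nn2)c1`: < 10%
compound 3 `O=C(NO)c1cccc(-c2cn([C@H]3C[C@@H](C(=O)O)N(CCCc4ccccc4)C3)nn2)c1`: < 10%

In an assay on Sf9 cells for inhibition of histone deacetylase 11 (Homo sapiens), read by fluorescence, tested at 0.5 uM (on this read-out higher numbers stand for more inhibition at the one concentration tested (going by the name of the read-out) and lower numbers for less inhibition), compound 1 gives 12%. For compound 2 this assay reports only a limit, < 10%. For compound 3 it likewise reports only a limit, < 10%. Both of these sit at the limit of < 10% in this assay, at which 2 of the 3 values shown sit, so neither gives a number to compare against. The difference between the core of compound 2 and the core of compound 3 is not broken down here.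

Compound 2 and compound 1 differ in one place, (2-(hydroxycarbamoyl)ethenyl in place of 3-(hydroxycarbamoyl)phenyl on an aromatic carbon). The step that this change made is a number at least 2 percentage points higher from compound 2 to compound 1 (that floor lies within the scatter).

Compound 4 `O=C(/C=C/c1cn([C@H]2C[C@@H](C(=O)O)N(CCCc3ccccc3)C2)nn1)NO` has not yet been measured. It stands to compound 3 as compound 1 stands to compound 2: 2-(hydroxycarbamoyl)ethenyl in place of 3-(hydroxycarbamoyl)phenyl on an aromatic carbon, with the surroundings of the place described in the same words, so the change is the same. Its step is expected to match the earlier one, a number at least 1 percentage points higher from compound 3 to compound 4 (that floor lies within the scatter), which rests on compound 3 showing only a limit and on the earlier step being small. Compound 4 is therefore estimated at 11%, from 4% to 20%.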

Compound 4, a percentage reported as inhibition, at one concentration (the size of the read-out at that concentration, not a potency): 29%
Compound 4: the middle estimate sits 18 percentage points below what was measured; measured number outside the range, above it.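

In this assay, putting 2-(hydroxycarbamoyl)ethenyl in place of 3-(hydroxycarbamoyl)phenyl on an aromatic carbon gives a number at least 19 percentage points higher from compound 3 to compound 4 (beyond the scatter), so on the core of compound 3 the floor of the step clears the scatter. On the core of compound 1 the floor of the same change does not clear it, and the two steps cannot be said to match or to differ: the same change on two cores in this assay, a number at least 2 percentage points higher (that floor lies within the scatter) from compound 2 to compound 1 and a number at least 19 percentage points higher (beyond the scatter) from compound 3 to compound 4; the limit leaves it open whether they differ. Both steps start from a limit and so give only floors, and two cores are too few to establish how this change behaves across the series.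

The compounds shown leave open whether the step would persist with an amide or an amine on the core, where compound 1 carries hydroxymethyl and compound 4 a carboxylic acid. Going by these compounds, it also remains open how this assay would respond to a longer chain in place of 2-(hydroxycarbamoyl)ethenyl.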